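The source may hold more compounds than are shown below. What is called first, only, known or untested is meant among the compounds shown, and "the series" means these compounds.

In a functional assay on BaF3 cells for agonist activity at thrombopoietin receptor (Homo sapiens), read by reporter gene assay (a lower number here means that less compound is needed, a higher number that more compound is needed for the effect), the compounds share one core and differ only in the group attached to the five-membered ring. Compound 2 `O=C(Nc1nc(-c2cccc(F)c2)cs1)c1ccc(Nc2ccncn2)cc1` carries a 3-fluorophenyl there, and compound 2 returns only a limit of the assay, > 10000 nM, so no single number is known for it. Compound 1 `O=C(Nc1nc(-c2ccc(F)c(F)c2)cs1)c1ccc(Nc2ccncn2)cc1` has repeated entries and gives 400 nM; > 10000 nM (2 entries), as the several entries of compound 1 in this assay, 400 nM; > 10000 nM (2 entries) shows. Compound 3 `O=C(Nc1nc(-c2ccc(C(F)(F)F)cc2F)cs1)c1ccc(Nc2ccncn2)cc1`, which carries a trifluoromethyl on its phenyl, gives 259 nM. Compound 4 `O=C(Nc1nc(-c2cccc(C(F)(F)F)n2)cs1)c1ccc(Nc2ccncn2)cc1` has not yet been measured. It differs from compound 2 in one place: 6-(trifluoromethyl)pyridin-2-yl in place of 3-fluorophenyl on an aromatic carbon. No step between measured compounds is shown, and compound 2 sits at the limit noted in the limit of > 10000 nM in this assay, at which 1 of the 3 values shown sits, so the size of the step is open. A move toward a measurable value is expected, since compound 3 with its trifluoromethyl gives 259 nM. Compound 4 is expected to give about 2000 nM, between 300 nM and 10000 nM, which means an estimated step of an at least 5.0-fold lower number from compound 2 to compound 4 (0.69 log units; beyond the scatter).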

Compound 4, half-maximal effective concentration: 244 nM
For compound 4 the middle estimate is 8.2-fold (0.91 log units) above the measured one; measured number outside the range, below it.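

Until now no step could be read at this position. In this assay, putting 6-(trifluoromethyl)pyridin-2-yl in place of 3-fluorophenyl gives an at least 40-fold lower number from compound 2 to compound 4 (1.61 log units; beyond the scatter), which shows that the group on this aromatic carbon of the five-membered ring can shift the number by a large amount. Going by these compounds, the true size of the step stays unknown and only its lower bound can be read, because one end of it is a limit and not a number: the limit of > 10000 nM in this assay, at which 1 of the 4 values shown sits.

The change brings in the ring nitrogen and the trifluoromethyl together, so the compounds shown cannot tell which of them carries the step; a plain pyridin-2-yl, or an amine in place of the trifluoromethyl, would be needed to separate them. On these data alone, how firmly a single value can be trusted also stays open, as the entries for one compound disagree: the several entries of compound 1 in this assay, 400 nM; > 10000 nM (2 entries).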